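Cyano for Trifluoromethyl on a Plain Ring: Compound 4

The source may hold more compounds than are shown below. What is called first, only, known or untested is meant among the compounds shown, and "the series" means these compounds.

Of the compounds shown here, three from this study have been measured in an assay on CHO cells with metabotropic glutamate receptor 2 (Homo sapiens) as the target, read by FLIPR; a higher number here means that more compound is needed for the effect, a lower number that less compound is needed. Compound 1, `Cn1c(CN2CCN(c3nc(Cl)ccc3C(F)(F)F)CC2)nc2cc(C(F)(F)F)ccc21`, gives 2000 nM. Compound 3, `Cn1c(CN2CCN(c3nc(Cl)ccc3C(F)(F)F)CC2)nc2cc(C#N)ccc21`, gives 50.1 nM. Compound 2, `Cn1c(CN2CCN(c3ccc(C(F)(F)F)cc3)CC2)nc2ccccc21`, gives 200 nM; the difference between the core of compound 2 and the core of compound 1 is not broken down here.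

The change from compound 1 to compound 3 is cyano in place of trifluoromethyl on an aromatic carbon. It made a 40-fold lower number from compound 1 to compound 3 (1.60 log units; beyond the scatter).

Compound 4, `Cn1c(CN2CCN(c3ccc(C#N)cc3)CC2)nc2ccccc21`, is not yet measured. It differs from compound 2 by cyano in place of trifluoromethyl on an aromatic carbon. Within the data shown here, this is the same kind of change as the one from compound 1 to compound 3, but not the same: there the place was part of a fused or bridged system of two rings, meta to a fused ring and para to a fused ring, whereas here it is a six-membered aromatic ring of carbon only, para to a large group.

Compound 4 is expected to show a 6.7-fold lower number from compound 2 to compound 4 (0.82 log units; beyond the scatter). This expected step is taken smaller than the measured one because a 40-fold lower number from compound 1 to compound 3 (1.60 log units; beyond the scatter) was seen on a different ring, and a single example on one ring gives only loose guidance for another. Compound 4 is estimated at 30 nM, with the range 6 nM to 150 nM expected to hold most repeat measurements.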

Compound 4, half-maximal effective concentration: > 12500 nM
Compound 4 ended at the assay's limit; the forecaster's own chance of this, stated with the estimate: 2%; middle value at least 410-fold (2.61 log units) from the limit.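

In this assay compound 4 gives > 12500 nM, and this is a limit of the assay, not a number. The step reads an at least 62-fold higher number from compound 2 to compound 4 (1.79 log units; beyond the scatter), so cyano in place of trifluoromethyl on an aromatic carbon did not carry over from one core to the other, and the two examples run in opposite directions: the same change on two cores in this assay, a 40-fold lower number (1.60 log units; beyond the scatter) from compound 1 to compound 3 and an at least 62-fold higher number (1.79 log units; beyond the scatter) from compound 2 to compound 4, at least 2400-fold (3.39 log units) apart, beyond the scatter of two such steps. Going by these compounds, this shows that, in this series, the result of the change on one core gave no safe guide to its result on another, but it does not show what sets the two cores apart, and the full size of the new step stays unknown, as compound 4 stands at a limit: the limit of > 12500 nM in this assay, at which 1 of the 4 values shown sits.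

The core of compound 1 and the core of compound 2 differ in more than one place, and no compound shown separates those differences, so it remains open which of them goes with the reversal. Also open, on these data alone, is how other groups in place of trifluoromethyl on the core of compound 2, such as an amine or a carboxylic acid, would read in this assay.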